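Fluoro for chloro on the aryl group of compound 3

The source may report more compounds than this note shows. Statements on the series, on what has been measured and on what is new or still open speak of the compounds shown alone.

Values in a functional assay on HL-60 cells (Homo sapiens) for inhibition, read by MTT assay, with a stated time of 48 h, tested at 10 uM (a higher number here means more inhibition of growth at the concentration tested, a lower number less inhibition of growth), so far:
compound 1 `Cc1oc2c([C@H]3CCN(C)C[C@H]3O)c(O)cc(O)c2c(=O)c1C(O)c1ccc([N+](=O)[O-])cc1` gives 0%
compound 2 `Cc1oc2c([C@H]3CCN(C)C[C@H]3O)c(O)cc(O)c2c(=O)c1C(O)c1ccccc1Br` gives 52%
compound 3 `Cc1oc2c([C@H]3CCN(C)C[C@H]3O)c(O)cc(O)c2c(=O)c1C(O)c1c(Cl)cccc1Cl` gives 14%

Compound 3 is the second highest of the three, above compound 1 and below compound 2. The next structure is compound 4 `Cc1oc2c([C@H]3CCN(C)C[C@H]3O)c(O)cc(O)c2c(=O)c1C(O)c1c(F)cccc1Cl` and the change to it is fluoro in place of chloro on an aromatic carbon in which 2,6-dichlorophenyl becomes 2-chloro-6-fluorophenyl. This is fluoro in place of chloro on an aromatic carbon, ortho to a large group and meta to a chloro group.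

Going by the values given here, no measured step makes this exchange directly. The nearest evidence comes from replacing the whole aryl group, and these steps are large or modest: a number 52 percentage points higher from compound 1 to compound 2 (beyond the scatter) then a number 14 percentage points higher from compound 1 to compound 3 (beyond the scatter) and a number 38 percentage points lower from compound 2 to compound 3 (beyond the scatter) on the same read-out. They show that this group can move the number considerably, but they do not fix a direction for a single halogen exchange. With compound 3 at 14% in the lower part of the measured span, and compound 2 at 52% as the upper mark, a small upward move is the more likely outcome. The expected step is a number 8 percentage points higher from compound 3 to compound 4 (within the scatter) with considerable uncertainty. The estimate for compound 4 is 22% with an expected range from 5% to 48% in this assay read-out.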

Compound 4, percent growth inhibition at one concentration: 49%
The estimate for compound 4 lay 27 percentage points below the measured number; the whole stated range lies below it.
By their numbers in this assay, from the lowest: compound 1; then compound 3; then compounds 4 and 2 (each within the scatter of the next).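

In this assay, fluoro in place of chloro on an aromatic carbon, ortho to a large group and meta to a chloro group, gives a number 35 percentage points higher from compound 3 to compound 4 (beyond the scatter), so a single halogen exchange at this place can produce a large step, which the earlier compounds had shown only for replacement of the whole aryl group. The 2-chloro-6-fluorophenyl and 2-bromophenyl groups are not separated here, with a number 3 percentage points lower from compound 2 to compound 4 (within the scatter), while a number 49 percentage points higher from compound 1 to compound 4 (beyond the scatter) sets compound 4 clear of the 4-nitrophenyl compound, and among the three halogen-bearing aryl groups the 2,6-dichlorophenyl group of compound 3 is the one that goes against a shared high reading. Nothing measured here accounts for the size of the step from chloro to fluoro.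

The compounds shown leave open whether this step depends on the remaining chloro group, which a second fluoro in its place would begin to test. Also open, on these data alone, is how this place responds to a group other than a halogen, such as methoxy or an amine, in place of the fluoro.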